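Benzyl for phenyl on the diethoxy core

A few compounds are considered here, and "the series" means these few. Any claim that something is new, unique, unknown or untested is made for them only; others in the source may bear on it.

The series shares one bicyclic acetal core, seen in compound 1 `O[C@@H]1[C@@H](O)[C@H](c2ccccc2)O[C@@H]2CO[C@@H](c3ccc(C(F)(F)F)cc3)O[C@@H]12`, which in a functional assay on HEL cells (Homo sapiens) for cytotoxicity (on this read-out higher numbers stand for lower toxicity in this test and lower numbers for higher toxicity in this test), gives 400 ug/mL. Compound 3 `CCCCCO[C@@H]1[C@@H](OCCCCC)[C@H](c2ccccc2)O[C@@H]2CO[C@@H](c3ccccc3)O[C@@H]12` carries two pentyloxy groups and in this assay gives 16 ug/mL; the two numbers lie well apart, the diol reading as the less toxic of the pair. Within the data shown here, compound 2 `CCO[C@@H]1[C@@H](OCC)[C@H](c2ccccc2)O[C@@H]2CO[C@@H](c3ccccc3)O[C@@H]12`, the diethoxy analogue, in this assay gives "not determined" (no result reported), so its standing among the others cannot be stated and no step from it can be sized. Compound 4 `CCO[C@@H]1[C@@H](OCC)[C@H](Cc2ccccc2)O[C@@H]2CO[C@@H](c3ccccc3)O[C@@H]12` differs from compound 2 in one place: benzyl in place of phenyl on a saturated ring carbon. Among the measured compounds shown here, with no measured step for this change, the direction and size of its effect in this assay are open, and the working assumption is a change that stays within the scatter of repeated measurements. Compound 4 is expected to fall between the readings of compound 1 and compound 3, estimated at 100 ug/mL with a range of 25 ug/mL to 400 ug/mL.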

Compound 4, minimum cytotoxic concentration: > 120 ug/mL
Compound 4 was reported as a limit (the forecaster's own chance of this, stated with the estimate: 30%); middle value at least 1.2-fold (0.07 log units) from the limit.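

No step can be read between compound 2 and compound 4: compound 2 has no reported result in this assay. Compound 4 gives a limit, not a number: the limit of > 120 ug/mL in this assay, at which 1 of the 4 values shown sits.

The compounds shown leave open what benzyl in place of phenyl does to the reading in this assay.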